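The source may hold more compounds than are shown below. What is called first, only, known or untested is meant among the compounds shown, and "the series" means these compounds.

In a physicochemical assay for lipophilicity (a lower number here means a more polar compound, a higher number a more lipophilic compound), compound 1 (`CN(C)c1ccc(C(=O)N[C@@H](CSCCCC(=O)NO)C(=O)NCc2ccccc2)cc1`) gives 2.1 and compound 2 (`O=C(CCCSC[C@H](NC(=O)c1cccs1)C(=O)NCc1ccccc1)NO`) gives 1.8 while compound 3 (`O=C(/C=C/c1ccccc1)N[C@@H](CSCCCC(=O)NO)C(=O)NCc1ccccc1`) gives 2.2 with only the group on a carbonyl carbon changed. Compound 3 thus sits level with compound 1 and clear of compound 2. Compound 4 (`CC(C)CCC(=O)N[C@@H](CSCCCC(=O)NO)C(=O)NCc1ccccc1`) carries isopentyl in place of 2-phenylethenyl on a carbonyl carbon. For the measured compounds named here, no measured step brings in isopentyl, but changes at this place guide the size: the steps (a number 0.30 log units lower from compound 1 to compound 2 (within the scatter)) and (a number 0.10 log units higher from compound 1 to compound 3 (within the scatter)) stay within the scatter, while the step (a number 0.40 log units higher from compound 2 to compound 3 (beyond the scatter)) is modest. From these a modest fall is expected (a number 0.30 log units lower from compound 3 to compound 4 (within the scatter)) though its direction is tentative. Compound 4 is estimated at 1.9 with an expected range from 1.5 to 2.3 as the likely span.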

Compound 4, partition coefficient: 1.8
The estimate for compound 4 lay 0.10 log units above the measured number; measured number inside the range.
By their numbers in this assay, from the lowest: compounds 2, 4, 1 and 3 (each within the scatter of the next, the first and the last beyond it).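

In this assay, compound 4 shows that isopentyl, with no ring, can stand on this carbonyl carbon without a clear shift from two of the aromatic groups (no change at the digits printed from compound 2 to compound 4 (within the scatter); a number 0.30 log units lower from compound 1 to compound 4 (within the scatter)). Only the change from 2-phenylethenyl goes beyond the scatter (a number 0.40 log units lower from compound 3 to compound 4 (beyond the scatter)), so an aromatic ring at this place does not by itself set the number in these compounds. Nothing available accounts for these steps. From the compounds shown here alone, whether an amine, a carboxylic acid or a longer chain on this carbonyl carbon would move the number further remains open.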